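The compounds below may be only part of what the source reports. "The series", "measured", "known", "first", "only" and "open" are said of these compounds alone.

Of the compounds shown here, two have so far been tested in a functional assay on MCF7 cells (Homo sapiens) for antiproliferative activity, read by MTT assay, with stated times of 24 h and 72 h; on this read-out lower numbers stand for stronger inhibition and higher numbers for weaker inhibition. Compound 1, `COc1ccc([C@@H]2[C@@H](Oc3ccccc3)C(=O)N2c2cc(OC)c(OC)c(OC)c2)cc1`, gives 6900 nM. Compound 2, `COc1cc(N2C(=O)[C@@H](Oc3ccccc3)[C@H]2c2ccc(N(C)C)cc2)cc(OC)c1OC`, gives 31000 nM, the higher of the two numbers, and the gap between them lies beyond the usual scatter of the measurement. Compound 3, `COc1cc(N2C(=O)[C@@H](Oc3ccccc3)[C@H]2c2ccc([S+](C)[O-])cc2)cc(OC)c1OC`, has not yet been measured. It differs from compound 2 in a single place: a group of 3 heavy atoms (1 carbon, 1 oxygen, 1 sulfur; no ring) in place of a group of 3 heavy atoms (2 carbon, 1 nitrogen; no ring), on an aromatic carbon. Within the data shown here, no measured pair shows this particular change, so its effect cannot be read off the data and must be estimated. The expected step is small, a 1.6-fold lower number from compound 2 to compound 3 (0.19 log units; within the scatter), with a slight lean toward a lower number but not one that can be called beyond the scatter. Compound 3 is therefore estimated at 20000 nM in this assay, within a range from 5000 nM to 80000 nM.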

Compound 3, half-maximal inhibitory concentration: 20000 nM
The estimate for compound 3 equals the measured number at the digits printed; measured number inside the range.
By their numbers in this assay, from the lowest: compound 1; then compounds 3 and 2 (each within the scatter of the next).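

Among these compounds, the step at this position, where dimethylamino leaves and a group of 3 heavy atoms (1 carbon, 1 oxygen, 1 sulfur) enters on an aromatic carbon para to a large group, is a 1.6-fold lower number from compound 2 to compound 3 (0.19 log units; within the scatter) in this assay, the first single-place comparison. The two groups have the same heavy-atom count and the same hydrogen-bond donor and acceptor counts, neither has a ring or a net charge, and exchanging a nitrogen-bearing group for a sulfur-bearing one here does not separate the two compounds beyond the scatter. Nothing available accounts for this result.

From the compounds shown here alone, whether a hydroxyl, a primary amine, a carboxylic acid or a longer chain at this place would stand apart from dimethylamino remains open. A single step also leaves open whether the same exchange would read alike on another core.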